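This account rests on a few compounds, and the source may have more. Where it says the series, first, only, none or still open, it means among the compounds named here.

Measured so far:
Compound 1 `CC(=O)c1cc(-c2ccccc2)cc2cc(-c3ccccc3)[nH]c12`: 60.9%
Compound 2 `CC(=O)c1cc(-c2ccc(F)cc2)cc2cc(-c3ccccc3)[nH]c12`: 55.7%

In a functional assay on HeLa cells (Homo sapiens) for cytotoxicity, read by MTT assay, with a stated time of 2 days, tested at 10 uM (on this read-out higher numbers stand for a weaker effect at the one concentration tested and lower numbers for a stronger effect), compound 2 gives 55.7%; compound 1 gives 60.9%, and the step of a number 5.2 percentage points lower from compound 1 to compound 2 (within the scatter) places the two within the scatter of each other, so neither stands apart. Compound 3 `COc1ccc(-c2cc(C(C)=O)c3[nH]c(-c4ccccc4)cc3c2)cc1` differs from compound 2 by methoxy in place of fluoro on an aromatic carbon. Among the compounds with values here, no measured step exchanges fluoro for methoxy; the only step known, a number 5.2 percentage points lower from compound 1 to compound 2 (within the scatter), stayed within the scatter. Compound 3 is therefore expected to show no step beyond the scatter, a number 2.3 percentage points higher from compound 2 to compound 3 (within the scatter). Compound 3 is estimated at 58%, with a range from 45% to 71%.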

Compound 3, a percentage reported as activity, at one concentration (the size of the read-out at that concentration, not a potency): 33.9%
Beside the measured number, compound 3's estimate is 24.1 percentage points above it; measured number outside the range, below it.
By their numbers in this assay, from the lowest: compound 3; then compounds 2 and 1 (each within the scatter of the next).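

The 4-fluorophenyl to 4-methoxyphenyl change in this assay brings a step (a number 21.8 percentage points lower from compound 2 to compound 3 (beyond the scatter)), and against the unsubstituted phenyl the picture is the same (a number 27 percentage points lower from compound 1 to compound 3 (beyond the scatter)). This position, para to a large group, can therefore move the read-out beyond the scatter toward a stronger effect, which fluoro in place of hydrogen did not do. Nothing measured on these compounds accounts for the change.

The compounds shown leave open whether a hydroxy group, a longer alkoxy chain or an amine on this carbon would act as methoxy does. They also leave open whether methoxy elsewhere on the shared core would give a similar step.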